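Aryl Chloro Position Shift in a Cytotoxicity Series

The source may report more compounds than this note shows. Statements on the series, on what has been measured and on what is new or still open speak of the compounds shown alone.

Measured compounds:
- compound 1, `COc1ccc(-c2cc(C)c(Nc3ccnc(Nc4ccc(C#N)cc4)n3)c(C)c2)cc1`, 2890 nM
- compound 2, `Cc1cc(-c2cccc(C(F)(F)F)c2)cc(C)c1Nc1ccnc(Nc2ccc(C#N)cc2)n1`, 4030 nM
- compound 3, `Cc1cc(-c2ccc(Cl)cc2)cc(C)c1Nc1ccnc(Nc2ccc(C#N)cc2)n1`, 4190 nM

In an ADME assay on MT4 cells (Homo sapiens) for cytotoxicity, read by MTT assay, with a stated time of 4 days (a lower number here means that less compound is tolerated, a higher number that more compound is tolerated), the three compounds sit close together. Compound 3 gives the highest of the three numbers, yet its separation from the others is small: a 1.0-fold higher number from compound 2 to compound 3 (0.02 log units; within the scatter) and a 1.4-fold higher number from compound 1 to compound 3 (0.16 log units; within the scatter). The remaining pair is no different in kind, with a 1.4-fold higher number from compound 1 to compound 2 (0.14 log units; within the scatter). So far, swapping the substituent on the outer aromatic ring, whether by group or by position, has left the cytotoxicity reading essentially unchanged.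

Compound 4, `Cc1cc(-c2cccc(Cl)c2)cc(C)c1Nc1ccnc(Nc2ccc(C#N)cc2)n1`, has not yet been measured. It is built from compound 3 by a change in which (3-chlorophenyl in place of 4-chlorophenyl on an aromatic carbon). Within the data shown here, the closest precedent is the step between compound 2 and compound 3, where a substituent moved between ring positions with a 1.0-fold higher number from compound 2 to compound 3 (0.02 log units; within the scatter); the other steps are of the same order. On that basis no step beyond the usual scatter is expected in this assay.

Compound 4 is therefore estimated at 4000 nM, within a range of 2000 nM to 8000 nM. The expected step is a 1.0-fold lower number from compound 3 to compound 4 (0.02 log units; within the scatter).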

Compound 4, half-maximal cytotoxic concentration: 2160 nM
The estimate for compound 4 lay 1.9-fold (0.27 log units) above the measured number, and the stated range covers the measured number.
By their numbers in this assay, from the lowest: compounds 4, 1, 2 and 3 (each within the scatter of the next).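

Compound 4 separates two kinds of change that the step between compound 2 and compound 3 had combined, since that step altered both the group and where it sits. With chloro kept and only its position changed, this assay shows a 1.9-fold lower number from compound 3 to compound 4 (0.29 log units; within the scatter), the largest step in this set but still one that gives no firm difference between 3-chlorophenyl and 4-chlorophenyl at this place on the shared core. With the position kept and only the group changed, there is a 1.9-fold lower number from compound 2 to compound 4 (0.27 log units; within the scatter), while the exchange of the whole outer ring gives a 1.3-fold lower number from compound 1 to compound 4 (0.13 log units; within the scatter), so neither chloro in place of trifluoromethyl nor 3-chlorophenyl in place of 4-methoxyphenyl separates compound 4 from its neighbours, and no measurement here offers a reason for the size of any of these steps.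

The compounds shown leave open whether an amine or a carboxylic acid on the outer ring would move the reading beyond the scatter in this assay. They also leave open whether a longer chain in place of chloro, at either of the two ring positions seen here, would do so.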